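The compounds below may be only part of what the source reports. "The series", "measured", "known", "first", "only" and "open" are said of these compounds alone.

Working notes on the series. In a functional assay on the whole organism (strain Sprague-Dawley) for inhibition, with Rattus norvegicus as the target, with a stated time of 10 min (on this read-out higher numbers stand for an effect only at larger amounts of compound and lower numbers for an effect already at smaller amounts), compound 1 (`O=C(O)c1cnc(-c2ccccc2OCC2CC2)[nH]c1=O`) stands at 0.1 mg/kg and compound 3 (`CCOC(=O)c1cnc(-c2ccccc2OCC(C)C)[nH]c1=O`) at 3 mg/kg as the higher of the two numbers in hand, with a gap between them that lies beyond the scatter. For compound 2 (`CCOC(=O)c1cnc(-c2ccccc2N)[nH]c1=O`) the entry reads "not determined" (no result reported) and offers no comparison.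

Compound 4 (`CCOC(=O)c1cnc(-c2ccccc2OCC2CC2)[nH]c1=O`) differs from compound 3 by cyclopropyl in place of isopropyl on a saturated chain carbon bound to an oxygen on an aromatic ring, which also reads as isobutoxy to cyclopropylmethoxy. Compound 1 carries the same cyclopropylmethoxy group but differs from compound 4 elsewhere, so its value does not isolate this change. Within the data shown here, no measured step covers the change, so the expectation starts from compound 3 at 3 mg/kg and allows only a modest shift. The expected step of a 1.5-fold lower number from compound 3 to compound 4 (0.18 log units; within the scatter) is small and toward a lower number, and it may stay within the scatter. In this assay the estimate for compound 4 is 2 mg/kg with an expected range of 0.5 mg/kg to 6 mg/kg for a single measurement.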

Compound 4, dose for 50% inhibition: 0.3 mg/kg
Compound 4: middle estimate off by 6.7-fold (0.82 log units), on the high side, outside the stated range (below it).
By their numbers in this assay, from the lowest: compound 1; then compound 4; then compound 3.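

In this assay, among these compounds, cyclopropyl in place of isopropyl on a saturated chain carbon bound to an oxygen on an aromatic ring gives a 10-fold lower number from compound 3 to compound 4 (1.00 log units; beyond the scatter), the first readable step at this position; both groups count the same heavy atoms, so the shift goes with the three-membered ring replacing the open branch. With cyclopropylmethoxy held constant, ethyl in place of hydrogen on an oxygen next to a carbonyl group gives a 3.0-fold higher number from compound 1 to compound 4 (0.48 log units; beyond the scatter), so the ester and the carboxylic acid also differ beyond the scatter. Nothing in hand explains either step.

Going by these compounds, whether a cyclobutyl ring or a longer chain at this position would follow cyclopropyl remains open. So does whether the gap between ester and carboxylic acid would persist with isobutoxy in place of cyclopropylmethoxy.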